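A Dimethoxy Change Against a Growth Inhibition Limit

This account rests on a few compounds, and the source may have more. Where it says the series, first, only, none or still open, it means among the compounds named here.

In a functional assay on MCF7 cells (Homo sapiens) for inhibition, read by sulforhodamine B assay, with a stated time of 48 h (a higher number here means a weaker inhibitor of growth, a lower number a stronger inhibitor of growth), compound 1 (`O=C(Cc1csc2nc(-c3ccc(Br)cc3)cn12)N/N=C/c1ccccc1O`) gives > 100000 nM as its result, and this is a limit of the assay and not a number. In this assay compound 2 (`O=C(Cc1csc2nc(-c3ccc(Br)cc3)cn12)N/N=C/c1ccc(O)cc1`) gives > 100000 nM as its result, and this too is only a limit. Compound 2 therefore stands with compound 1 at the limit of > 100000 nM in this assay, at which 2 of the 2 values shown sit, and has no number to start from. For the measured compounds named here, the one measured step is a step that the two limits leave unreadable from compound 1 to compound 2 and it offers no size to carry forward, although it concerns the same carbon with a double bond to nitrogen.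

In compound 3 (`COc1cccc(OC)c1/C=N/NC(=O)Cc1csc2nc(-c3ccc(Br)cc3)cn12`) 2,6-dimethoxyphenyl takes the place of 4-hydroxyphenyl on that carbon, a difference of 2,6-dimethoxyphenyl in place of 4-hydroxyphenyl on a carbon with a double bond to nitrogen in all. Since compound 2 gives > 100000 nM as a limit, no step beyond the usual scatter is expected in this assay and the likeliest report is another limit. The estimated change is a number no higher from compound 2 to compound 3 (the limit leaves the size open) with no direction expected. Compound 3 is estimated at 100000 nM (expected range 50000 nM to 200000 nM).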

Compound 3, concentration for total growth inhibition: > 100000 nM
Compound 3: no number, only a limit (the forecaster's own chance of this, stated with the estimate: 85%); the middle value lies on the limit itself.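

In this assay compound 3 gives > 100000 nM, a limit of the assay and not a number, so no step can be read from compound 2 or compound 1 to compound 3. All three compounds stand together: the limit of > 100000 nM in this assay, at which 3 of the 3 values shown sit. The compounds shown leave open what number any of them would have, and whether any group on the carbon with a double bond to nitrogen would give a readable value.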